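Ring Size at the Aromatic Nitrogen: Compound 1 to Compound 4

The source may report more compounds than this note shows. Statements on the series, on what has been measured and on what is new or still open speak of the compounds shown alone.

Compound 1 `CN1CCN(c2ccc(Nc3ncc4nc(Nc5ccc(F)cc5)n([C@H]5CCCN(S(=O)(=O)C6CC6)C5)c4n3)cc2)CC1` gives 8.6 nM in a functional assay on HCC827 cells (Homo sapiens) for antiproliferative activity, read by MTT assay, with a stated time of 72 h (on this read-out higher numbers stand for weaker inhibition and lower numbers for stronger inhibition), the lowest of the three numbers. Compound 2 `CC(=O)Nc1cccc(-n2c(Nc3ccc(F)cc3)nc3cnc(Nc4ccc(N5CCN(C)CC5)cc4)nc32)c1` gives 10 nM in this assay, and the step of a 1.2-fold higher number from compound 1 to compound 2 (0.07 log units; within the scatter) is within the scatter. Compound 3 `CN1CCN(c2ccc(Nc3ncc4nc(Nc5ccc(F)cc5)n([C@@H]5CCN(C(=O)CO)C5)c4n3)cc2)CC1` gives 350 nM, with a 41-fold higher number from compound 1 to compound 3 (1.61 log units; beyond the scatter) and a 35-fold higher number from compound 2 to compound 3 (1.54 log units; beyond the scatter). Compound 4 `CN1CCN(c2ccc(Nc3ncc4nc(Nc5ccc(F)cc5)n([C@H]5CCN(S(=O)(=O)C6CC6)C5)c4n3)cc2)CC1` differs from compound 1 only by 1-(cyclopropylsulfonyl)pyrrolidin-3-yl in place of 1-(cyclopropylsulfonyl)piperidin-3-yl on an aromatic nitrogen. Going by the values given here, the step from compound 1 to compound 3 also brings one five-membered non-aromatic ring in place of the six-membered one, but it exchanges the cyclopropylsulfonyl group at the same time, so no measured step isolates the ring size alone. Because compound 1 gives 8.6 nM while the combined change gave a 41-fold higher number from compound 1 to compound 3 (1.61 log units; beyond the scatter), compound 4 is expected to show at most a modest rise, a 1.7-fold higher number from compound 1 to compound 4 (0.24 log units; within the scatter), with an estimated 15 nM (range 5 nM to 60 nM).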

Compound 4, half-maximal inhibitory concentration: 7.5 nM
Compound 4: middle estimate off by 2.0-fold (0.30 log units), on the high side; the range from low to high includes it.
By their numbers in this assay, from the lowest: compounds 4, 1 and 2 (each within the scatter of the next); then compound 3.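

Holding the cyclopropylsulfonyl group fixed isolates ring size at this aromatic nitrogen: 1-(cyclopropylsulfonyl)pyrrolidin-3-yl in place of 1-(cyclopropylsulfonyl)piperidin-3-yl gives a 1.1-fold lower number from compound 1 to compound 4 (0.06 log units; within the scatter) in this assay. With the five-membered ring held, the large step instead follows the group on its ring nitrogen, as cyclopropylsulfonyl in place of (hydroxymethyl)carbonyl gives a 47-fold lower number from compound 3 to compound 4 (1.67 log units; beyond the scatter). The 3-acetamidophenyl group also shows no step beyond the scatter, with a 1.3-fold lower number from compound 2 to compound 4 (0.12 log units; within the scatter).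

No supporting data explain these steps. As far as these compounds go, whether an amine or a carboxylic acid in place of the cyclopropylsulfonyl group would keep such low numbers remains open.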